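This account rests on a few compounds, and the source may have more. Where it says the series, first, only, none or still open, it means among the compounds named here.

Within the data shown here, in a functional assay on A549 cells (Homo sapiens) for antiproliferative activity, read by MTT assay, with a stated time of 72 h (a lower number here means a stronger inhibitor, a higher number a weaker inhibitor), three compounds sharing one core have numbers so far. Compound 1 `CC(C)=CC(=O)Nc1cccc(Oc2nc(Nc3ccn(C)n3)nc3c2CSCC3)c1` gives 44200 nM, compound 2 `C/C=C/C(=O)Nc1cccc(Oc2nc(Nc3cccc(OC)c3)nc3c2CSCC3)c1` gives 21100 nM, and compound 3 `CCC/C=C/C(=O)Nc1cccc(Oc2nc(Nc3cccc(OC)c3)nc3c2CSCC3)c1` gives 11800 nM. Compound 3 thus lies within the scatter of compound 2 and beyond the scatter of compound 1. Compound 4 `COc1cccc(Nc2nc3c(c(Oc4cccc(NC(=O)C=C(C)C)c4)n2)CSCC3)c1` changes one group of compound 3: 2-methylprop-1-en-1-yl in place of pent-1-en-1-yl on a carbonyl carbon. Among the measured compounds shown here, the one measured step at this place, a 1.8-fold lower number from compound 2 to compound 3 (0.25 log units; within the scatter), stayed within the scatter, so no step beyond the scatter is expected in this assay. The estimated change is a 1.4-fold higher number from compound 3 to compound 4 (0.16 log units; within the scatter). For compound 4 the expected value is 17000 nM, with an estimated range from 8000 nM to 38000 nM.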

Compound 4, half-maximal inhibitory concentration: 19800 nM
For compound 4 the middle estimate is 1.2-fold (0.07 log units) below the measured one; measured number inside the range.
By their numbers in this assay, from the lowest: compounds 3, 4 and 2 (each within the scatter of the next); then compound 1.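

In this assay, changing the chain on the carbonyl carbon again stays within the scatter (a 1.7-fold higher number from compound 3 to compound 4 (0.22 log units; within the scatter); a 1.1-fold lower number from compound 2 to compound 4 (0.03 log units; within the scatter)), so prop-1-en-1-yl, pent-1-en-1-yl and 2-methylprop-1-en-1-yl cannot be told apart here. The change on the nitrogen on an aromatic ring, 3-methoxyphenyl in place of 1-methyl-1H-pyrazol-3-yl, goes modestly beyond it (a 2.2-fold lower number from compound 1 to compound 4 (0.35 log units; beyond the scatter)). Nothing available explains either result. On these data alone, whether an amine or a carboxylic acid on that chain would move the number further remains open, as does whether the 3-methoxyphenyl gain holds with other carbonyl groups.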